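The source may report more compounds than this note shows. Statements on the series, on what has been measured and on what is new or still open speak of the compounds shown alone.

Compound 1 `CCC(CC)Nc1nc(OC)c(-c2ccc(Cl)cc2Cl)nc1C`: 14.4 nM
Compound 2 `CCc1nc(-c2ccc(OC(F)(F)F)cc2OC)c(CC)nc1NC(CC)CC`: 7.2 nM
Compound 3 `CCC(CC)Nc1nc(C)c(-c2ccc(Cl)cc2Cl)nc1C`: 27 nM

All three were tested in an assay on IMR-32 cells for displacement of a labelled ligand from corticotropin-releasing factor receptor 1 (Homo sapiens), read by scintillation counting, with a stated time of 2 h; a lower number here means a stronger inhibitor, a higher number a weaker inhibitor. Among the three numbers, compound 2 has the lowest, but its gap to compound 1 lies within the scatter, so these two cannot be told apart; only its gap to compound 3 lies beyond the scatter. Compound 4 `CCc1nc(-c2ccc(OC(F)(F)F)cc2OC)c(OC)nc1NC(CC)CC` has not yet been measured. It differs from compound 2 in one place: methoxy in place of ethyl on an aromatic carbon. Within the data shown here, one measured step bears on this change, the one from compound 1 to compound 3, where a methyl took the place of a methoxy on the shared core and gave a 1.9-fold higher number from compound 1 to compound 3 (0.27 log units; within the scatter). The change from compound 2 to compound 4 runs the other way, an ethyl giving way to a methoxy, so for compound 4 in this assay the expected number lies close to that of compound 2, if anything a little lower, without a step beyond the scatter: a 1.4-fold lower number from compound 2 to compound 4 (0.16 log units; within the scatter). Compound 4 is estimated at 5 nM, with a range from 2 nM to 15 nM.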

Compound 4, inhibition constant: 6.1 nM
Compound 4: middle estimate off by 1.2-fold (0.09 log units), on the low side; the range from low to high includes it.
By their numbers in this assay, from the lowest: compounds 4, 2, 1 and 3 (each within the scatter of the next, the first and the last beyond it).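

Tested in this assay with the rest of the molecule unchanged, replacing the ethyl next to the ring nitrogen with a methoxy gives a change within the scatter (a 1.2-fold lower number from compound 2 to compound 4 (0.07 log units; within the scatter)). The swap keeps the count of heavy atoms and adds a hydrogen-bond acceptor, so on the core of compound 2 this acceptor brings no measurable gain or loss. The earlier evidence at this position compared methoxy with methyl on a different core, so this result extends the picture to an ethyl group, though no measured property explains it.

Going by these compounds, whether a longer chain such as butyl, or an amine or a carboxylic acid, would also leave the number unmoved at this position remains open. Also open, on these data alone, is whether ethyl and methoxy would match on the core of compound 1.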